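The source may report more compounds than this note shows. Statements on the series, on what has been measured and on what is new or still open speak of the compounds shown alone.

Measured in a physicochemical assay for lipophilicity, read by HPLC, measured as octanol-water partition, at pH 7; on this read-out lower numbers stand for lower lipophilicity and higher numbers for higher lipophilicity:
- compound 1 `Cc1cc(OC(=O)C(C)(C)CCC(CO[N+](=O)[O-])O[N+](=O)[O-])n(-c2ccccc2)n1` gives 4.04
- compound 2 `Cc1cc(OC(=O)C(C)(C)CCCCO[N+](=O)[O-])n(-c2ccccc2)n1` gives 4.3
- compound 3 `Cc1cc(OC(=O)c2ccc(OCC(CO[N+](=O)[O-])O[N+](=O)[O-])cc2)n(-c2ccccc2)n1` gives 5.14

Compound 4 `Cc1cc(OC(=O)c2ccc(OCCCO[N+](=O)[O-])cc2)n(-c2ccccc2)n1` has not yet been measured in this assay. Compound 4 differs from compound 3 in one place: hydrogen in place of nitrooxy on a saturated chain carbon bound to two saturated chain carbons. The same change, at the same kind of place, separates compound 1 from compound 2: hydrogen in place of nitrooxy on a saturated chain carbon bound to two saturated chain carbons. In this assay that earlier change gave a number 0.26 log units higher from compound 1 to compound 2 (within the scatter). The difference between the core of compound 1 and the core of compound 3 is not broken down here. Among the three measured compounds, compound 3 stands highest, with gaps to compound 2 and compound 1 beyond the scatter.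

Among the compounds with values here, for compound 4 a step of about the same size is expected, a number 0.26 log units higher from compound 3 to compound 4 (within the scatter), resting on a number 0.26 log units higher from compound 1 to compound 2 (within the scatter) as the only instance of this change measured so far. Compound 4 is therefore estimated at 5.4, expected to fall between 5.05 and 5.75.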

Compound 4, partition coefficient: 4.74
Beside the measured number, compound 4's estimate is 0.66 log units above it; measured number below the stated range.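

In this assay hydrogen in place of nitrooxy on a saturated chain carbon bound to two saturated chain carbons gives a number 0.40 log units lower from compound 3 to compound 4 (beyond the scatter) and, on the other core, a number 0.26 log units higher from compound 1 to compound 2 (within the scatter) so a step read on the core of compound 1 does not transfer as a fixed increment to the core of compound 3. With a single pair on each core, this shows only that the result of the change depends on the core here, not how it would run on any third core. Nothing shown bears on why the two cores differ.

Open, from the compounds shown here alone, is whether a third core would follow either pair. Also open, going by these compounds, is how an amine or a carboxylic acid in place of nitrooxy at that carbon would read, or how a longer chain would.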